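Halogen swap on the benzyl ether of a flavonol

This account rests on a few compounds, and the source may have more. Where it says the series, first, only, none or still open, it means among the compounds named here.

Compound 3 `O=c1c(O)c(-c2ccccc2)oc2cc(OCc3cccc(Br)c3)cc(O)c12` was tested in an ADME assay on Huh-5-2 cells (Homo sapiens) for cytotoxicity, read by WST assay, with a stated time of 3 days; on this read-out higher numbers stand for lower toxicity in this test and lower numbers for higher toxicity in this test. Compound 3 gives > 100000 nM, which is a limit of the assay and not a number. Compound 1 `O=c1c(O)c(-c2ccccc2)oc2cc(OCc3ccccc3Cl)cc(O)c12` sits at the same position: in this assay compound 1 gives > 100000 nM, again a limit rather than a measured value. Only compound 2 `Cc1ccccc1COc1cc(O)c2c(=O)c(O)c(-c3ccccc3)oc2c1` yields a number, 17000 nM in this assay. The measured steps are therefore an at least 5.8-fold lower number from compound 1 to compound 2 (0.76 log units; beyond the scatter) and an at least 5.8-fold higher number from compound 2 to compound 3 (0.76 log units; beyond the scatter), while a step that the two limits leave unreadable from compound 1 to compound 3. Two of the three values rest at the same ceiling, as the limit of > 100000 nM in this assay, at which 2 of the 3 values shown sit, shows.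

Compound 4 `O=c1c(O)c(-c2ccccc2)oc2cc(OCc3ccc(Cl)cc3)cc(O)c12` differs from compound 3 in one place: 4-chlorophenyl in place of 3-bromophenyl on a saturated chain carbon bound to an oxygen on an aromatic ring. Among the measured compounds shown here, no measured step covers a move between two halogenated phenyl groups, since the only pair of that kind is unreadable. For the measured compounds named here, both halogen-bearing compounds 1 and 3 sit at the limit, and the single readable step, from a chloro to a methyl, runs toward higher toxicity. Compound 4 is therefore expected to stay near the limit, with the step of a number no higher from compound 3 to compound 4 (the limit leaves the size open) expected to be nothing beyond the scatter. Compound 4 is estimated at 100000 nM, with a range from 40000 nM to 250000 nM.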

Compound 4, half-maximal cytotoxic concentration: > 100000 nM
Compound 4 gave a limit, no number (the forecaster's own chance of this, stated with the estimate: 70%); the middle value sits exactly at the limit.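

The 2-chlorophenyl of compound 1, the 3-bromophenyl of compound 3 and the 4-chlorophenyl of compound 4 now all give a limit rather than a number in this assay, so the ceiling holds for a third halogen-bearing phenyl group on this saturated chain carbon, and it is the most common result in the set: the limit of > 100000 nM in this assay, at which 3 of the 4 values shown sit.

Among the compounds shown here, the only new step that can be read is an at least 5.8-fold higher number from compound 2 to compound 4 (0.76 log units; beyond the scatter), which leaves compound 2, with its 2-methylphenyl, as the one compound of the four with a measured value. The new steps among the compounds at the limit cannot be read, so these compounds show no difference between chlorine and bromine, or between one named halogen-bearing phenyl group and another.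

Still open, going by these compounds, is whether the lower number of compound 2 belongs to the methyl group itself or to the 2-methylphenyl arrangement, which a 4-methylphenyl group would help to separate. Also open, on these data alone, is whether a phenyl group carrying an amine or a carboxylic acid would stay at the limit or yield a number.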